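Swapping a cyclopropyl for a methoxypyridine: clearance outlook

The source may hold more compounds than are shown below. What is called first, only, known or untested is meant among the compounds shown, and "the series" means these compounds.

Of the compounds shown here, three sharing one core have been tested in an ADME assay (liver) for metabolic stability, with Liver microsome (Homo sapiens) as the target, using microsomes and NADPH, with a stated time of 30 min, tested at 1 uM; on this read-out higher numbers stand for fast clearance and lower numbers for slow clearance. Compound 1 `Nc1ccc(S(=O)(=O)N2CCN(c3ncc(C(O)(C(F)(F)F)C(F)(F)F)cc3C3CC3)CC2)cn1` gives 38 mL.min-1.g-1, the highest of the three numbers. Compound 2 `COCC#Cc1cc(C(O)(C(F)(F)F)C(F)(F)F)cnc1N1CCN(S(=O)(=O)c2ccc(N)nc2)CC1` gives 15 mL.min-1.g-1, and compound 3 `Nc1ccc(S(=O)(=O)N2CCN(c3ncc(C(O)(C(F)(F)F)C(F)(F)F)cc3-c3cnccc3F)CC2)cn1` gives 17 mL.min-1.g-1. The two measured steps away from compound 1 both lower the number: a 2.5-fold lower number from compound 1 to compound 2 (0.40 log units; beyond the scatter) and a 2.2-fold lower number from compound 1 to compound 3 (0.35 log units; beyond the scatter). Between the two replacements the gap is small, as a 1.1-fold higher number from compound 2 to compound 3 (0.05 log units; within the scatter) shows.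

Compound 4 `COc1ccc(-c2cc(C(O)(C(F)(F)F)C(F)(F)F)cnc2N2CCN(S(=O)(=O)c3ccc(N)nc3)CC2)cn1` has not yet been measured. It differs from compound 1 in one place: 6-methoxypyridin-3-yl in place of cyclopropyl on an aromatic carbon. For the measured compounds named here, of the measured steps, the one from compound 1 to compound 3 is the closest match. There too a six-membered aromatic ring with one nitrogen enters on the same aromatic carbon in place of cyclopropyl, and it gave a 2.2-fold lower number from compound 1 to compound 3 (0.35 log units; beyond the scatter). The step to compound 2 points the same way. On that basis a modest fall in this assay is expected for compound 4, of about a 1.9-fold lower number from compound 1 to compound 4 (0.28 log units; within the scatter). The estimate for compound 4 is therefore 20 mL.min-1.g-1, with a plausible range from 10 mL.min-1.g-1 to 40 mL.min-1.g-1; a methoxy group is new here, so the range is kept wide.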

Compound 4, intrinsic clearance in microsomes: 25 mL.min-1.g-1
Estimate against measurement, compound 4: 1.3-fold (0.10 log units) below; measured number inside the range.
By their numbers in this assay, from the lowest: compounds 2, 3, 4 and 1 (each within the scatter of the next, the first and the last beyond it).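

In this assay, the 6-methoxypyridin-3-yl group, with 8 heavy atoms against the 3 of cyclopropyl, gives a step that stays within the scatter (a 1.5-fold lower number from compound 1 to compound 4 (0.18 log units; within the scatter)). A six-membered aromatic ring with one nitrogen on this carbon therefore does not by itself set a compound clearly apart from compound 1, which compound 3 alone might have suggested. Compound 4 also cannot be told apart from the other two replacements (a 1.5-fold higher number from compound 3 to compound 4 (0.17 log units; within the scatter); a 1.7-fold higher number from compound 2 to compound 4 (0.22 log units; within the scatter)), so across these four compounds the number shows no clear link with the size of the group on this carbon.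

No measurement shown here explains these numbers. A plain pyridin-3-yl would help separate the contribution of the ring from that of its methoxy group, while a saturated amine such as morpholin-4-yl would test whether an aromatic ring is needed on this carbon at all.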